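This account rests on a few compounds, and the source may have more. Where it says the series, first, only, none or still open, it means among the compounds named here.

Measured in a functional assay on A549 cells (Homo sapiens) for inhibition, read by MTT assay, with a stated time of 48 h; on this read-out higher numbers stand for weaker inhibition and lower numbers for stronger inhibition:
- compound 1 `COc1ccc(N(C)c2nc(C)nc3ccccc23)cc1C(=O)OCCCC[Se]C#N`: 155 nM
- compound 2 `COc1ccc(N(C)c2nc(C)nc3ccccc23)cc1OCC[Se]C#N`: 13 nM
- compound 3 `COc1ccc(N(C)c2nc(C)nc3ccccc23)cc1OCCCC[Se]C#N`: 1200 nM

Compound 3, at 1200 nM, has the highest number of the three and is therefore the weakest inhibitor in this small set. Compound 4 `COc1ccc(N(C)c2nc(C)nc3ccccc23)cc1OCCCCC[Se]C#N` has not yet been measured. It differs from compound 3 in one place: a group of 4 heavy atoms (2 carbon, 1 nitrogen, 1 selenium; no ring) in place of a group of 3 heavy atoms (1 carbon, 1 nitrogen, 1 selenium; no ring), on a saturated chain carbon, four bonds along the chain from an oxygen on an aromatic ring, on a saturated chain carbon, four bonds along the chain from an oxygen on an aromatic ring. Put simply, the chain gets longer.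

The closest guide is a 92-fold higher number from compound 2 to compound 3 (1.97 log units; beyond the scatter), a large step in which the same chain also grew. The other two steps, a 12-fold lower number from compound 1 to compound 2 (1.08 log units; beyond the scatter) and a 7.7-fold higher number from compound 1 to compound 3 (0.89 log units; beyond the scatter), say less, as each also removes the carbonyl of compound 1 from the link to the ring. A single comparable pair cannot show whether the rise continues or levels off. A further large jump is therefore not assumed, and only a small upward move in this assay is expected, possibly none beyond the scatter. The estimated change is a 1.7-fold higher number from compound 3 to compound 4 (0.22 log units; within the scatter). For compound 4 the estimated value is 2000 nM, with an expected range of 300 nM to 10000 nM.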

Compound 4, half-maximal inhibitory concentration: 2440 nM
For compound 4 the middle estimate is 1.2-fold (0.09 log units) below the measured one, within the range that was stated.
By their numbers in this assay, from the lowest: compound 2; then compound 1; then compound 3; then compound 4.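

In this assay, one more lengthening of the chain gives a 2.0-fold higher number from compound 3 to compound 4 (0.31 log units; beyond the scatter), so the number keeps rising past compound 3, but this step is far smaller than the earlier one, a 92-fold higher number from compound 2 to compound 3 (1.97 log units; beyond the scatter). Across the compounds that share the oxygen link, the whole span is a 190-fold higher number from compound 2 to compound 4 (2.27 log units; beyond the scatter), with most of that climb in the first lengthening and only a modest addition in the second, and the longest chain also ends up weaker than the carbonyl-bearing compound, with a 16-fold higher number from compound 1 to compound 4 (1.20 log units; beyond the scatter). Nothing shown here explains why the first lengthening costs so much more than the second.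

From the compounds shown here alone, whether a still longer chain, such as one with another carbon or two added, would keep raising the number or level off remains open, as does whether a chain shorter than that of compound 2 would lower it further. The compounds shown also leave open how a thiocyanate end group, with sulfur in place of selenium, would behave on these same chains.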